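The compounds below may be only part of what the source reports. "The series", "measured", "known", "first", "only" and "open" are said of these compounds alone.

Compound 1, `O=[N+]([O-])c1cn2c(n1)OC[C@@H](OCc1cnn(-c3ccc(C(F)(F)F)cc3)c1)C2`, is tested in an ADME assay on Vero cells (Chlorocebus sabaeus) for cytotoxicity, with a stated time of 72 h; a lower number here means a stronger inhibitor, a higher number a weaker inhibitor. In this assay compound 1 reaches only the limit of the measurement, at > 128000 nM. Compound 2, `O=[N+]([O-])c1cn2c(n1)OC[C@@H](OCc1cnn(-c3ccc(F)cc3)c1)C2`, carries the change fluoro in place of trifluoromethyl on an aromatic carbon relative to compound 1. In this assay compound 2 likewise stops at the limit, at > 128000 nM. The step that the two limits leave unreadable from compound 1 to compound 2 therefore cannot be read, since both ends of it are limits rather than numbers.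

Compound 3, `O=[N+]([O-])c1cn2c(n1)OC[C@@H](OCc1cnn(-c3ccc(C(F)(F)F)cc3)n1)C2`, has a different core from compound 1; the difference between the two cores is not broken down here. In this assay compound 3 also sits at the limit, at > 128000 nM. Among the compounds with values here, the one piece of evidence across the measured compounds is the limit of > 128000 nM in this assay, at which 3 of the 3 values shown sit, so no measured step in this assay has a readable size at all.

Compound 4, `O=[N+]([O-])c1cn2c(n1)OC[C@@H](OCc1cnn(-c3ccc(F)cc3)n1)C2`, has not yet been measured. It differs from compound 3 by fluoro in place of trifluoromethyl on an aromatic carbon, the same change that separates compound 1 from compound 2, made on the same kind of place. Because the limit of > 128000 nM in this assay, at which 3 of the 3 values shown sit, puts every measured value at the limit, the step from compound 3 to compound 4 is expected to be unreadable in the same way, a number no higher from compound 3 to compound 4 (the limit leaves the size open). Compound 4 is expected to give 128000 nM in this assay, estimated to lie between 64000 nM and 256000 nM, most likely as a limit rather than a number.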

Compound 4, half-maximal inhibitory concentration: > 128000 nM
Compound 4 ended at the assay's limit (the forecaster's own chance of this, stated with the estimate: 85%); the middle value lies on the limit itself.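

In this assay, within the data shown here, compound 3 and compound 4 both give limits rather than numbers, so the step between them, like the one between compound 1 and compound 2, cannot be read. All the compounds shown share one result: the limit of > 128000 nM in this assay, at which 4 of the 4 values shown sit. Left open is how far each compound's true value lies from that limit, and so whether fluoro in place of trifluoromethyl changes the read-out at all.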